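This account rests on a few compounds, and the source may have more. Where it says the series, first, only, none or still open, it means among the compounds named here.

In a functional assay on MCF7 cells (Homo sapiens) for inhibition (on this read-out lower numbers stand for stronger inhibition and higher numbers for weaker inhibition), compound 1 (`CC/C=C/C=C/[C@@]1(C)SC(O)=CC1=O`) gives 16.9 ug/mL and compound 2 (`CCCCCC[C@@]1(C)SC(=O)C=C1OCCCCCl`) gives 8.6 ug/mL, so these two numbers lie within the usual scatter of each other. Compound 3 (`CCCCCC[C@@]1(C)SC(=O)C=C1OCC(=O)NCCCBr`) keeps the core of compound 2 but carries one structural change: (3-bromopropyl)carbamoyl in place of 3-chloropropyl on a saturated chain carbon bound to an oxygen on an unsaturated carbon. In words, (3-bromopropyl)carbamoyl stands in place of 3-chloropropyl on a saturated chain carbon bound to an oxygen on an unsaturated carbon. Among the compounds with values here, no measured pair of compounds shows this kind of change, so the expected step, a 1.2-fold higher number from compound 2 to compound 3 (0.07 log units; within the scatter), stays within the scatter. Compound 3 is estimated at 10 ug/mL, with an expected range from 4 ug/mL to 25 ug/mL.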

Compound 3, half-maximal inhibitory concentration: 6.7 ug/mL
Estimate against measurement, compound 3: 1.5-fold (0.17 log units) above; the measured number falls inside the stated range.
By their numbers in this assay, from the lowest: compounds 3, 2 and 1 (each within the scatter of the next, the first and the last beyond it).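

Putting (3-bromopropyl)carbamoyl in place of 3-chloropropyl on a saturated chain carbon bound to an oxygen on an unsaturated carbon gives a 1.3-fold lower number from compound 2 to compound 3 (0.11 log units; within the scatter), so this position tolerates a group of 7 heavy atoms instead of 4, with a hydrogen-bond donor and acceptor added. The carbamoyl unit and bromine in place of chlorine arrive together, so the step cannot be divided between them. Nothing available explains the result.

Going by these compounds, whether the halogen matters at all remains open. An amine or a carboxylic acid at the chain end would probe this position further.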